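Working notes: amide change from compound 2 to compound 3

The compounds below may be only part of what the source reports. "The series", "measured", "known", "first", "only" and "open" are said of these compounds alone.

compound 1 `CN1CCc2nc(C#Cc3cccc(F)c3)sc2C1` — > 10000 nM
compound 2 `CCC(=O)N1CCc2nc(C#Cc3ccccc3)sc2C1` — > 10000 nM

In an assay on HEK293 cells for positive allosteric modulation of metabotropic glutamate receptor 5 (Homo sapiens), read by FLIPR, with a stated time of 1 h (a higher number here means that more compound is needed for the effect, a lower number that less compound is needed), compound 1 returns only a limit, > 10000 nM. In this assay compound 2 likewise returns only a limit, > 10000 nM. Within the data shown here, compound 2 therefore stands at the edge of what this assay reports, and the one other value shown sits at the same place (the limit of > 10000 nM in this assay, at which 2 of the 2 values shown sit). Among the measured compounds shown here, neither measured compound gives a number, so no step between measured compounds can be sized.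

Compound 3 `COC1CC(C(=O)N2CCc3nc(C#Cc4ccccc4)sc3C2)C1` differs from compound 2 by 3-methoxycyclobutyl in place of ethyl on a carbonyl carbon. With both measured values at the limit, there is nothing to anchor a direction, and the expected step of an at least 1.2-fold lower number from compound 2 to compound 3 (0.09 log units; that floor lies within the scatter) is set as a modest gain at most, well within the uncertainty. The estimate for compound 3 in this assay is 8000 nM, with a range from 1500 nM to 30000 nM, and a real chance that only a limit is reported again.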

Compound 3, half-maximal effective concentration: 640 nM
Estimate against measurement, compound 3: 13-fold (1.10 log units) above; the whole stated range lies above it.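

In this assay, 3-methoxycyclobutyl in place of ethyl on a carbonyl carbon gives an at least 15-fold lower number from compound 2 to compound 3 (1.19 log units; beyond the scatter), and compound 3 is the first compound shown with a measured number rather than a limit. The group on this carbonyl carbon can therefore move the read-out off the limit, at least when the amide-type nitrogen in a ring and the rest of the core are unchanged. The step is a floor and not a full size, because compound 2 sits at a limit: the limit of > 10000 nM in this assay, at which 2 of the 3 values shown sit.

The change brings in the four-membered ring and the methoxy group together, so the compounds shown cannot assign the step to either one. Going by these compounds, whether plain cyclobutyl, or a hydroxyl or an amine in place of the methoxy group, would keep a measured number remains open.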